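The source may report more compounds than this note shows. Statements on the series, on what has been measured and on what is new or still open speak of the compounds shown alone.

Going by the values given here, in a functional assay on HL-60 cells (Homo sapiens) for inhibition, read by resazurin assay, with a stated time of 72 h (on this read-out higher numbers stand for weaker inhibition and lower numbers for stronger inhibition), compound 2 (`COc1cc(N2C(=O)C(Oc3ccccc3)C2c2ccc(SC)cc2)cc(OC)c1OC`) gives 388 nM, the higher of the two numbers so far, while compound 1 (`COc1ccc(C2C(C3CC3)C(=O)N2c2cc(OC)c(OC)c(OC)c2)cc1`) gives 156 nM, a gap beyond the usual scatter. Compound 3 (`COc1cc(N2C(=O)C(C3CC3)C2c2ccc(SC)cc2)cc(OC)c1OC`) has cyclopropyl in place of phenoxy on a saturated ring carbon of compound 2: cyclopropyl in place of phenoxy on a saturated ring carbon. Among the compounds with values here, no measured pair isolates this change, but compound 1 also carries cyclopropyl and gives 156 nM. A moderate move towards stronger inhibition in this assay is therefore expected, with an estimated step of a 2.3-fold lower number from compound 2 to compound 3 (0.36 log units; beyond the scatter). Compound 3 is expected at 170 nM, within an estimated range of 50 nM to 500 nM.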

Compound 3, half-maximal inhibitory concentration: 279 nM
Beside the measured number, compound 3's estimate is 1.6-fold (0.22 log units) below it, within the range that was stated.
By their numbers in this assay, from the lowest: compounds 1, 3 and 2 (each within the scatter of the next, the first and the last beyond it).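

In this assay, cyclopropyl in place of phenoxy on the saturated ring carbon gives a 1.4-fold lower number from compound 2 to compound 3 (0.14 log units; within the scatter) and so does not separate the two groups at this position, although phenoxy brings an aromatic ring and an oxygen. With cyclopropyl held in place, methylsulfanyl in place of methoxy on an aromatic carbon gives a 1.8-fold higher number from compound 1 to compound 3 (0.25 log units; within the scatter) and likewise leaves the two compounds unseparated. Nothing available gives a reason for either step. Still open, as far as these compounds go, is whether an amine or a carboxylic acid on this ring carbon would give a number beyond the scatter from those of compound 2 and compound 3.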